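The source may report more compounds than this note shows. Statements on the series, on what has been measured and on what is new or still open speak of the compounds shown alone.

Measured so far in an ADME assay on SH-SY5Y cells (Homo sapiens) for cytotoxicity, read by MTT assay, with a stated time of 72 h (a higher number here means a weaker inhibitor, a lower number a stronger inhibitor), each entry being a limit of the assay and not a number:

- Compound 1 `COc1ccc2[nH]cc(CCCN3CCN(C(=O)CN4CCN(C(=O)c5ccc(C)cc5)CC4)CC3)c2c1` gives > 200000 nM
- Compound 2 `COc1ccc2[nH]cc(CCCN3CCN(C(=O)CN4CCN(C(=O)c5cccc(Cl)c5)CC4)CC3)c2c1` gives > 200000 nM
- Compound 3 `COc1cccc(C(=O)N2CCN(CC(=O)N3CCN(CCCc4c[nH]c5ccc(OC)cc45)CC3)CC2)c1` gives > 200000 nM

Compound 3 sits at > 200000 nM as a limit, so it has no exact place on the scale. The other two measured compounds offer no firmer reference (the limit of > 200000 nM in this assay, at which 3 of the 3 values shown sit).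

Compound 4 `COc1ccc2[nH]cc(CCCN3CCN(C(=O)CN4CCN(C(=O)c5ccccc5Br)CC4)CC3)c2c1` has not yet been measured. It carries 2-bromophenyl in place of 3-methoxyphenyl on a carbonyl carbon.

Going by the values given here, three measured steps bear on this change: a step that the two limits leave unreadable from compound 1 to compound 2 and a step that the two limits leave unreadable from compound 1 to compound 3 and a step that the two limits leave unreadable from compound 2 to compound 3 give no size to carry over. With no readable size to build on, no change beyond the scatter is expected in this assay, and no direction is favoured. The expected move is a number no higher from compound 3 to compound 4 (the limit leaves the size open) and nothing larger. The estimate for compound 4 is 200000 nM with an expected range from 100000 nM to 300000 nM and the assay may well report only a limit again.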

Compound 4, half-maximal inhibitory concentration: 111000 nM
For compound 4 the middle estimate is 1.8-fold (0.26 log units) above the measured one; the range from low to high includes it.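

In this assay, going by these compounds alone, compound 4, with 2-bromophenyl on the carbonyl carbon, gives the first value that is a number, whereas the steps among compound 1, compound 2 and compound 3 cannot be read. Against those earlier compounds the change reads as an at least 1.8-fold lower number from compound 3 to compound 4 (0.25 log units; that floor lies within the scatter), an at least 1.8-fold lower number from compound 2 to compound 4 (0.25 log units; that floor lies within the scatter) and an at least 1.8-fold lower number from compound 1 to compound 4 (0.25 log units; that floor lies within the scatter), so each step gives only a floor, and none of these floors goes beyond the scatter. The three earlier compounds stay at a limit of the assay and not at a number: the limit of > 200000 nM in this assay, at which 3 of the 4 values shown sit.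

From the compounds shown here alone, the true size of these steps stays open, so it is not settled that 2-bromophenyl differs from the other three groups in this assay. Also open, going by these compounds, is how a phenyl carrying an amine or a carboxylic acid would read on this carbonyl carbon.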